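The compounds below may be only part of what the source reports. "The series", "measured", "known", "first", "only" and "open" are said of these compounds alone.

Of the compounds shown here, three built on one shared core have been tested in an ADME assay on GES1 cells (Homo sapiens) for cytotoxicity, read by MTT assay, with a stated time of 24 h; on this read-out higher numbers stand for lower toxicity in this test and lower numbers for higher toxicity in this test. Compound 1 `CC1(C)[C@H]2CC[C@]1(C)N(Cc1cn(-c3ccc(C#N)cc3)nn1)C(=O)C2` gives 11300 nM. Compound 2 `CC1(C)[C@H]2CC[C@]1(C)N(Cc1cn(-c3ccccc3C#N)nn1)C(=O)C2` gives 9450 nM, and compound 3 `CC1(C)[C@H]2CC[C@]1(C)N(Cc1cn(-c3ccccc3)nn1)C(=O)C2` gives 6690 nM. Compound 1 holds the highest of these three numbers, yet the others sit close: the step of a 1.2-fold lower number from compound 1 to compound 2 (0.08 log units; within the scatter) and the step of a 1.7-fold lower number from compound 1 to compound 3 (0.23 log units; within the scatter) both stay inside the scatter of repeated measurements, as does a 1.4-fold lower number from compound 2 to compound 3 (0.15 log units; within the scatter). Across these three, moving the nitrile on the phenyl ring or taking it away altogether has left the read-out essentially where it was.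

Compound 4 `CC1(C)[C@H]2CC[C@]1(C)N(Cc1cn(-c3cccc(Br)c3)nn1)C(=O)C2` is the next candidate. Relative to compound 1, the change is 3-bromophenyl in place of 4-cyanophenyl on an aromatic nitrogen. Among the measured compounds shown here, none of the measured compounds carries a bromine, so the three small steps above are the only guide, and every one of them stayed within the scatter. The expectation is therefore a step no larger than the scatter, with a 1.3-fold lower number from compound 1 to compound 4 (0.12 log units; within the scatter) as the expected step. Compound 4 is estimated at 8500 nM in this assay, within a range from 4000 nM to 18000 nM.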

Compound 4, half-maximal cytotoxic concentration: 9930 nM
Estimate against measurement, compound 4: 1.2-fold (0.07 log units) below, and the stated range covers the measured number.
By their numbers in this assay, from the lowest: compounds 3, 2, 4 and 1 (each within the scatter of the next).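

Replacing 4-cyanophenyl with 3-bromophenyl on the aromatic nitrogen changes both the substituent and its place on the phenyl ring, yet in this assay the result is only a 1.1-fold lower number from compound 1 to compound 4 (0.06 log units; within the scatter) for this double change. Bromo in place of hydrogen gives a 1.5-fold higher number from compound 3 to compound 4 (0.17 log units; within the scatter) as the comparison with the bare phenyl group, and the swap from the other nitrile-bearing ring gives a 1.1-fold higher number from compound 2 to compound 4 (0.02 log units; within the scatter) as the third reading, so a bromine is now added to the nitrile and the bare phenyl as a substituent pattern that stays within the scatter. The entering group counts no hydrogen-bond acceptor where 4-cyanophenyl counts one, and even so the read-out does not move beyond the scatter, although nothing in the data accounts for this insensitivity.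

On these data alone, all four compounds carry a six-membered aromatic ring of carbon only on that nitrogen, so it remains open whether a ring bearing an amine or a carboxylic acid would shift the number beyond the scatter. As far as these compounds go, a longer alkyl chain in place of the phenyl ring is equally open, as is any change to the shared core.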